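Swapping methyl for chloro on a furan substituent

A few compounds are considered here, and "the series" means these few. Any claim that something is new, unique, unknown or untested is made for them only; others in the source may bear on it.

Measured compounds:
Compound 1 `Nc1nc(-c2ccco2)nc2sc(CN3CCCC3)cc12`: 6430 nM
Compound 2 `Cc1ccc(-c2nc(N)c3cc(CN4CCCC4)sc3n2)o1`: 620 nM
Compound 3 `Cc1ccc(-c2nc(N)c3cc(CN4CCCCC4)sc3n2)o1`: 610 nM

All three were tested in an assay on CHO-K1 cells for antagonist activity at adenosine receptor A1 (Homo sapiens), read by a beta-galactosidase reporter, with stated times of 15 min and 6 h; a higher number here means a weaker inhibitor, a lower number a stronger inhibitor. Compound 2 sits second highest of the three numbers: its nearest neighbour is compound 3, and the two lie within the scatter of each other, as a 1.0-fold lower number from compound 2 to compound 3 (0.01 log units; within the scatter) shows. Compound 1 is the furthest away, with a much higher number, and the step of a 10-fold lower number from compound 1 to compound 2 (1.02 log units; beyond the scatter) is well beyond the scatter.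

Compound 4 `Nc1nc(-c2ccc(Cl)o2)nc2sc(CN3CCCC3)cc12` has not yet been measured. It differs from compound 2 in one place: chloro in place of methyl on an aromatic carbon. Among the measured compounds shown here, no measured step exchanges a methyl for a chloro, so no step bears directly on this change. The step of a 10-fold lower number from compound 1 to compound 2 (1.02 log units; beyond the scatter) shows that the same position is sensitive to what sits there, but it says nothing about chloro against methyl. A step of unknown direction, likely within or close to the scatter, is therefore expected in this assay, namely a 1.1-fold higher number from compound 2 to compound 4 (0.05 log units; within the scatter). Compound 4 is estimated at 700 nM, with a range from 200 nM to 2500 nM.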

Compound 4, inhibition constant: 710 nM
Estimate against measurement, compound 4: 1.0-fold (0.01 log units) below; low and high end bracket the measured number.
By their numbers in this assay, from the lowest: compounds 3, 2 and 4 (each within the scatter of the next); then compound 1.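

In this assay, methyl and chloro on this carbon next to the ring oxygen cannot be told apart, as a 1.1-fold higher number from compound 2 to compound 4 (0.06 log units; within the scatter) shows. Compared with hydrogen at the same carbon, chloro also gives a clearly lower number, with a 9.1-fold lower number from compound 1 to compound 4 (0.96 log units; beyond the scatter) beside a 10-fold lower number from compound 1 to compound 2 (1.02 log units; beyond the scatter) for methyl, so among these compounds the gain over hydrogen is not tied to methyl alone. Nothing available here explains why either group has this effect.

On these data alone, it remains open whether other groups on this carbon, such as bromo, methoxy, trifluoromethyl or an amine, would fit the same picture. As far as these compounds go, it is also open whether chloro would give a similar number with piperidin-1-yl in place of pyrrolidin-1-yl on the side chain.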